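From an Acetyl Group to an Isopropylcarbamoyl Group

The source may report more compounds than this note shows. Statements on the series, on what has been measured and on what is new or still open speak of the compounds shown alone.

Compound 3 `CC(=O)Nc1nc2ccc(NC(=O)c3c(Cl)cccc3Cl)cc2s1` is one of three compounds tested in a functional assay on WI-38 VA13 cells (Homo sapiens) for cytotoxicity; on this read-out higher numbers stand for an effect only at larger amounts of compound and lower numbers for an effect already at smaller amounts. In that assay compound 3 gives 0.6 ug/mL, the higher of the two numbers recorded. Compound 1 `O=C(Nc1ccc2nc(NC(=O)C3CCCCC3)sc2c1)c1ccccc1Oc1ccccc1` gives 0.1 ug/mL, a gap beyond the usual scatter. Compound 2 `O=C(Nc1ccc2nc(NC(=O)C3CCCCC3)sc2c1)c1ccc(Cl)cc1Cl` gives > 4 ug/mL, which is a limit of the assay and not a number (the limit of > 4 ug/mL in this assay, at which 1 of the 3 values shown sits). Compound 4 `CC(C)NC(=O)Nc1nc2ccc(NC(=O)c3c(Cl)cccc3Cl)cc2s1` differs from compound 3 by isopropylamino in place of methyl on a carbonyl carbon. Within the data shown here, no measured pair shows this change, so the size of the step in this assay is open; a shift toward a larger value, or none beyond the scatter, seems most likely. Compound 4 is expected to give 1 ug/mL, within 0.3 ug/mL to 4 ug/mL, a step estimated at a 1.7-fold higher number from compound 3 to compound 4 (0.22 log units; within the scatter).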

Compound 4, half-maximal effective concentration: 0.03 ug/mL
For compound 4 the middle estimate is 33-fold (1.52 log units) above the measured one; measured number outside the range, below it.
By their numbers in this assay, from the lowest: compound 4; then compound 1; then compound 3. At a limit, above all of these: compound 2.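

In this assay isopropylamino in place of methyl on a carbonyl carbon gives a 20-fold lower number from compound 3 to compound 4 (1.30 log units; beyond the scatter) and so shows that this position alone can move the read-out strongly. The earlier compounds shown here offered no pair differing in one place, so they could not show this. Here the change from acetamido to (isopropylcarbamoyl)amino brings the effect to smaller amounts of compound.

Going by these compounds, whether a tert-butylamino group or a morpholine on the same carbonyl carbon would go further remains open. Nothing given here accounts for the size of this step.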